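Compound 3 to compound 4: one group swapped

The source may hold more compounds than are shown below. What is called first, only, known or untested is meant among the compounds shown, and "the series" means these compounds.

Measured so far in a functional assay on HepG2 cells (Homo sapiens) for antiproliferative activity, with a stated time of 72 h (on this read-out lower numbers stand for an effect already at smaller amounts and higher numbers for an effect only at larger amounts of compound), each value a limit and not a number:
Compound 1 `COC(=O)c1cc(=O)c2cc(NC(=O)Nc3ccc(Cl)c(Cl)c3)ccc2[nH]1`: > 6350 nM
Compound 2 `COC(=O)c1cc(=O)c2cc(NC(=O)Nc3ccc(F)c(Cl)c3)ccc2[nH]1`: > 6350 nM
Compound 3 `COC(=O)c1cc(=O)c2cc(NC(=O)Nc3cccc(C(C)=O)c3)ccc2[nH]1`: > 8080 nM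

Compound 3 stands at > 8080 nM, which is a limit. The same is true of the other two compounds, so no real number exists yet to reason from.

Compound 4 `COC(=O)c1cc(=O)c2cc(NC(=O)Nc3ccc4c(c3)CCC4)ccc2[nH]1` carries 2,3-dihydro-1H-inden-5-yl in place of 3-acetylphenyl on an amide-type nitrogen. The counted change is 2,3-dihydro-1H-inden-5-yl in place of 3-acetylphenyl on an amide-type nitrogen.

Two measured steps changed the group on this same nitrogen: a step that the two limits leave unreadable from compound 1 to compound 3 and a step that the two limits leave unreadable from compound 2 to compound 3. A third, with fluoro in place of chloro on an aromatic carbon, is a step that the two limits leave unreadable from compound 1 to compound 2. None of the three has a readable size. Compound 1 and compound 2 sit at the limit of > 6350 nM in this assay, at which 2 of the 3 values shown sit. Compound 3 sits at the limit of > 8080 nM in this assay, at which 1 of the 3 values shown sits.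

No measured size can therefore be carried over, and no step beyond the scatter is expected. Compound 3 is the only anchor, with its limit of > 8080 nM, so a limit is the likeliest outcome again. The expected change is a step that the limit leaves unreadable from compound 3 to compound 4. For compound 4 the estimate is 9000 nM, with an expected range from 3500 nM to 25000 nM.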

Compound 4, half-maximal effective concentration: > 24100 nM
Compound 4 ended at the assay's limit (the forecaster's own chance of this, stated with the estimate: 85%); middle value at least 2.6-fold (0.42 log units) from the limit.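

In this assay compound 4 gives > 24100 nM, which is a limit and not a number. Compound 1, compound 2 and compound 3 also stand at limits, so the steps from each of them to compound 4 cannot be read. The compounds shown leave open whether any group on the amide-type nitrogen gives a measurable value in this assay.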